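This account rests on a few compounds, and the source may have more. Where it says the series, first, only, none or still open, it means among the compounds named here.

Measured compounds in a functional assay on SiHa cells (Homo sapiens) for cytotoxicity, with a stated time of 4 h; a higher number here means a weaker inhibitor, a lower number a stronger inhibitor:
compound 1 `CCc1ccc2c(c1)[n+]([O-])c(NCCN(C)C)n[n+]2[O-]` gives 500 nM
compound 2 `CCc1ccc2c(c1)[n+]([O-])c(NCCN1CCCCC1)n[n+]2[O-]` gives 1000 nM
compound 3 `CCOc1ccc2c(c1)[n+]([O-])c(NCCN1CCCCC1)n[n+]2[O-]` gives 1700 nM

Compound 1 stands at the low end of these three numbers: the step of a 2.0-fold higher number from compound 1 to compound 2 (0.30 log units; within the scatter) lies within the scatter, whereas the gap to compound 3 lies beyond it. Compound 4 `CC(C)Oc1ccc2c(c1)[n+]([O-])c(NCCN(C)C)n[n+]2[O-]` differs from compound 1 in one place: isopropoxy in place of ethyl on an aromatic carbon The measured step that bears on this change is a 1.7-fold higher number from compound 2 to compound 3 (0.23 log units; within the scatter), where ethoxy replaced ethyl on an aromatic carbon, a step within the scatter. Going by the values given here, no measured pair shows isopropoxy itself. For compound 4 a comparably small shift toward a higher number in this assay is therefore expected, a 1.6-fold higher number from compound 1 to compound 4 (0.20 log units; within the scatter), without a change beyond the scatter being assured. Compound 4 is estimated at 800 nM, expected to fall between 350 nM and 2000 nM.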

Compound 4, half-maximal inhibitory concentration: 1600 nM
Beside the measured number, compound 4's estimate is 2.0-fold (0.30 log units) below it; the range from low to high includes it.
By their numbers in this assay, from the lowest: compounds 1, 2, 4 and 3 (each within the scatter of the next, the first and the last beyond it).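

In this assay, isopropoxy in place of ethyl on this aromatic carbon gives a 3.2-fold higher number from compound 1 to compound 4 (0.51 log units; beyond the scatter), so a change at this position can carry the number beyond the scatter toward a weaker inhibitor. The earlier ethoxy step, a 1.7-fold higher number from compound 2 to compound 3 (0.23 log units; within the scatter), on the piperidinyl chain had not shown that. No measurement given here accounts for this shift.

The compounds shown leave open whether the oxygen or the branched isopropyl carbons matter more. An isopropyl or methoxy group on the same aromatic carbon would help separate the two.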